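A few compounds are considered here, and "the series" means these few. Any claim that something is new, unique, unknown or untested is made for them only; others in the source may bear on it.

Working notes on the amide series sharing one core.

Compound 1 `Cn1c(-c2ccc(NC(=O)CSc3nc4ccccc4o3)cc2)nc(-c2ccccc2)c1-c1ccccc1` gives 27.4% in a functional assay on MCF7 cells (Homo sapiens) for cytotoxicity, read by MTT assay, with a stated time of 24 h, tested at 1.6 ug/mL; on this read-out lower numbers stand for a weaker effect and higher numbers for a stronger effect at the one concentration tested. Compound 2 `Cn1nnnc1SCC(=O)Nc1ccc(-c2nc(-c3ccccc3)c(-c3ccccc3)n2C)cc1` gives 34.3% in this assay, and the step of a number 6.9 percentage points higher from compound 1 to compound 2 (within the scatter) is within the scatter. Compound 3 `CN1CCN(CC(=O)Nc2ccc(-c3nc(-c4ccccc4)c(-c4ccccc4)n3C)cc2)CC1` gives 2.9% in this assay, the lowest of the three numbers; the steps of a number 24.5 percentage points lower from compound 1 to compound 3 (beyond the scatter) and a number 31.4 percentage points lower from compound 2 to compound 3 (beyond the scatter) both lie beyond the scatter, so the 4-methylpiperazin-1-yl group on the saturated chain carbon bound to the carbonyl carbon goes with a clearly weaker effect than either sulfanyl group.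

Compound 4 `Cn1c(-c2ccc(NC(=O)CN3CCN(Cc4ccccc4)CC3)cc2)nc(-c2ccccc2)c1-c1ccccc1` differs from compound 3 in one place: phenyl in place of hydrogen on a saturated chain carbon bound to an amine nitrogen in a ring. Cut one bond further out, methyl becomes benzyl. Among the compounds with values here, no measured step touches this position; the two steps beyond the scatter, to compound 3 from compound 1 and from compound 2, concern the group on the chain carbon bound to the carbonyl carbon, not the group on the ring amine nitrogen. With nothing to anchor a direction, the expected step of a number 7.1 percentage points higher from compound 3 to compound 4 (within the scatter) in this assay is no change beyond the scatter, with the low starting point of compound 3 leaving more room upward than downward. Compound 4 is therefore expected to give about 10% in this assay, estimated between 0% and 28%.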

Compound 4, a percentage reported as activity, at one concentration (the size of the read-out at that concentration, not a potency): 13.3%
Beside the measured number, compound 4's estimate is 3.3 percentage points below it; low and high end bracket the measured number.
By their numbers in this assay, from the lowest: compound 3; then compound 4; then compounds 1 and 2 (each within the scatter of the next).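

Within the data shown here, this is the first measured change on a saturated chain carbon bound to an amine nitrogen in a ring: phenyl in place of hydrogen, or methyl to benzyl when cut one bond further out, goes with a number 10.4 percentage points higher from compound 3 to compound 4 (beyond the scatter) in this assay, a modest step. The earlier steps shown here all exchanged the whole group on the saturated chain carbon bound to a carbonyl carbon, so they could not show that the read-out also moves with a change further out on the 4-methylpiperazin-1-yl group, with the rest of the molecule held constant. Nothing available gives a measured reason for this step, and a single step at this position sets no trend.

Going by these compounds, whether the aromatic ring of the benzyl group matters, or simply a larger group on the ring amine nitrogen, stays open; a cyclohexylmethyl group would separate the two readings. How the read-out responds to a longer chain between that nitrogen and the phenyl ring, as in 2-phenylethyl, or to a fluorine or a methoxy group on the phenyl ring, is also left open by the compounds shown.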